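A few compounds are considered here, and "the series" means these few. Any claim that something is new, unique, unknown or untested is made for them only; others in the source may bear on it.

Measured compounds in an assay on a protein complex for inhibition of CDK8/Cyclin C (Homo sapiens), with a stated time of 1 h; on this read-out lower numbers stand for stronger inhibition and higher numbers for weaker inhibition:
- compound 1 `NC(=O)/C=C/c1ccncc1-c1ccc2ccccc2c1`: 10.5 nM
- compound 2 `CNC(=O)/C=C/c1ccncc1-c1ccc2ccccc2c1`: 12.4 nM
- compound 3 `O=C(O)[C@@H]1CCCN1C(=O)/C=C/c1ccncc1-c1ccc2ccccc2c1`: "not determined" (no result reported)

Compound 3 therefore has no place among the numbers shown: its potency in this assay is simply unknown, so the step to compound 4 `O=C(O)CCNC(=O)/C=C/c1ccncc1-c1ccc2ccccc2c1` cannot start from a measured value. The change is (2-carboxyethyl)amino in place of 2-carboxypyrrolidin-1-yl on a carbonyl carbon. Of the measured steps, only a 1.2-fold higher number from compound 1 to compound 2 (0.07 log units; within the scatter) touches the same part of the molecule, the amide nitrogen, and it lies within the scatter, which suggests that small changes at this nitrogen are tolerated. Among the measured compounds shown here, compound 4 keeps an amide hydrogen as compound 1 and compound 2 do, but carries a longer group, and no measured step tells how a carboxylic acid on that chain is received in this assay. The expectation is therefore guarded: compound 4 is estimated at 25 nM, with a range from 7 nM to 120 nM, near the values of compound 1 and compound 2 but with room for weaker inhibition.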

Compound 4, half-maximal inhibitory concentration: 870 nM
Beside the measured number, compound 4's estimate is 35-fold (1.54 log units) below it; measured number above the stated range.
By their numbers in this assay, from the lowest: compounds 1 and 2 (each within the scatter of the next); then compound 4.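

In this assay the amide nitrogen turns out to be far less forgiving than the swap of hydrogen for methyl suggested: adding 2-carboxyethyl gives an 83-fold higher number from compound 1 to compound 4 (1.92 log units; beyond the scatter) and extending the methyl to the same group gives a 70-fold higher number from compound 2 to compound 4 (1.85 log units; beyond the scatter) in a clear loss of inhibition. Compound 3 has no reported result, so the step from it to compound 4 cannot be read, and the exchange of 2-carboxypyrrolidin-1-yl for (2-carboxyethyl)amino remains without a measured effect. Nothing shown here explains the loss. Still open, as far as these compounds go, is whether the loss goes with the carboxylic acid or with the longer chain. A plain propyl chain or a methyl ester on the amide nitrogen would help separate these two possibilities.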